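The compounds below may be only part of what the source reports. "The series", "measured", "known", "first", "only" and "open" are said of these compounds alone.

In a functional assay on MCF7 cells (Homo sapiens) for antiproliferative activity, read by MTT assay, with a stated time of 48 h (a lower number here means a stronger inhibitor, a higher number a weaker inhibitor), three amides built on a shared core have been measured. Compound 1 `COc1ccc(C(=O)Nc2nnc(/C=C/c3cc(OC)c(OC)c(OC)c3Br)s2)cc1` gives 560 nM, compound 2 `COc1cc(/C=C/c2nnc(NC(=O)c3ccccc3Br)s2)c(Br)c(OC)c1OC` gives 370 nM, and compound 3 `COc1cc(/C=C/c2nnc(NC(=O)c3ccc(Cl)cc3)s2)c(Br)c(OC)c1OC` gives 280 nM. These numbers all lie within the usual scatter of one another, so compound 3 cannot be set apart from either of the other two.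

Compound 4 `COc1cc(/C=C/c2nnc(NC(=O)c3cccc(O)c3)s2)c(Br)c(OC)c1OC` keeps the core and has 3-hydroxyphenyl in place of 4-chlorophenyl on a carbonyl carbon.

The measured steps that bear on this change are a 1.5-fold lower number from compound 1 to compound 2 (0.18 log units; within the scatter), a 1.3-fold lower number from compound 2 to compound 3 (0.12 log units; within the scatter) and a 2.0-fold lower number from compound 1 to compound 3 (0.30 log units; within the scatter). All three exchange the group at this same place, and each stays within the scatter. Among the compounds with values here, none of the measured compounds carries the 3-hydroxyphenyl group, however, so the data offer no direct precedent for it.

Within the data shown here, the size of these steps, up to the one ending at compound 3 with 280 nM, suggests that no step beyond the scatter should be expected in this assay. The estimate leans slightly towards a higher number, and the expected change is a 1.4-fold higher number from compound 3 to compound 4 (0.13 log units; within the scatter). Compound 4 is expected at about 380 nM, with an estimated range of 150 nM to 950 nM.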

Compound 4, half-maximal inhibitory concentration: 360 nM
The estimate for compound 4 lay 1.1-fold (0.02 log units) above the measured number; the measured number falls inside the stated range.
By their numbers in this assay, from the lowest: compounds 3, 4, 2 and 1 (each within the scatter of the next).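

In this assay, putting 3-hydroxyphenyl in place of 4-chlorophenyl on the carbonyl carbon brings in 1 hydrogen-bond donor and 1 hydrogen-bond acceptor where the leaving group counts 0 of each, and the result is a 1.3-fold higher number from compound 3 to compound 4 (0.11 log units; within the scatter). Set against the other two amides, the same group gives a 1.0-fold lower number from compound 2 to compound 4 (0.01 log units; within the scatter) and a 1.6-fold lower number from compound 1 to compound 4 (0.19 log units; within the scatter), so a hydroxyl-bearing ring now joins the chloro-, bromo- and methoxy-bearing rings at this place, and no step among the four compounds goes beyond the scatter. Nothing available explains why these numbers stay so close together.

The four compounds all carry a substituted phenyl ring at this place, so they leave open whether a plain phenyl, or a ring bearing an amine or a carboxylic acid, would stay within the same narrow band. Within the data shown here, they also leave open whether a longer chain in place of the ring, or any change to the shared core itself, would produce the first step beyond the scatter.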